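The compounds below may be only part of what the source reports. "The series", "measured", "known", "first", "only" and "open" are said of these compounds alone.

Compounds so far in an assay on isolated protein for inhibition of histone deacetylase 8 (Homo sapiens), with a stated time of 1 h; on this read-out higher numbers stand for weaker inhibition and lower numbers for stronger inhibition:
- Compound 1, `Cc1ccc(NC(=O)COc2ccc3cc(/C=C4/SC(=O)NC4=O)ccc3c2)cc1`, gives 9000 nM.
- Compound 2, `O=C(COc1ccc2cc(/C=C3/SC(=O)NC3=O)ccc2c1)Nc1ccc(F)cc1F`, gives > 50000 nM, which is a limit of the assay.
- Compound 3, `COc1ccc(NC(=O)COc2ccc3cc(/C=C4/SC(=O)NC4=O)ccc3c2)cc1`, gives > 50000 nM, again a limit of the assay.

Compound 3 thus stands at the upper edge of what this assay reports, and it shares that position with one other value in the set; see (the limit of > 50000 nM in this assay, at which 2 of the 3 values shown sit). Compound 4, `Cc1ccc(NC(=O)COc2ccc3cc(/C=C4/SC(=O)NC4=O)ccc3c2)cc1Cl`, is not yet measured. It differs from compound 3 in one place: 3-chloro-4-methylphenyl in place of 4-methoxyphenyl on an amide-type nitrogen.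

Going by the values given here, two measured steps bear on this change. an at least 5.5-fold higher number from compound 1 to compound 3 (0.74 log units; beyond the scatter) shows that the methoxy group on the aryl amide costs activity relative to the methyl group of compound 1. an at least 5.5-fold higher number from compound 1 to compound 2 (0.74 log units; beyond the scatter) shows that the 2,4-difluorophenyl group costs a comparable amount. a step that the two limits leave unreadable from compound 2 to compound 3 cannot be read, since both ends are limits. Among the compounds with values here, compound 4 reinstates the 4-methyl group of compound 1 and adds a chlorine on the ring; no measured step isolates that chlorine, so its own contribution is unknown.

Compound 4 is therefore expected to recover at least part of the ground lost in compound 3, with an at least 3.3-fold lower number from compound 3 to compound 4 (0.52 log units; beyond the scatter) as the expected step, though the number may again fall at the limit. The estimate for compound 4 is 15000 nM, expected to lie between 4000 nM and 50000 nM.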

Compound 4, half-maximal inhibitory concentration: > 50000 nM
Compound 4 ended at the assay's limit; the forecaster's own chance of this, stated with the estimate: 35%; middle value at least 3.3-fold (0.52 log units) away from the limit.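

In this assay, chloro in place of hydrogen on an aromatic carbon of the aryl group of compound 1 gives an at least 5.5-fold higher number from compound 1 to compound 4 (0.74 log units; beyond the scatter), so keeping the methyl group does not by itself keep the activity of compound 1. Compound 4 gives > 50000 nM, which is a limit of the assay. Of the aryl groups on the amide-type nitrogen, only the 4-methylphenyl of compound 1 now gives a value that is not a limit, and the steps among compound 2, compound 3 and compound 4 cannot be read, as all three sit at the same edge: the limit of > 50000 nM in this assay, at which 3 of the 4 values shown sit.

Going by these compounds, how far compound 4 lies past that limit stays unknown, so the true size of the loss from the added chloro group cannot be set against the losses seen with the 4-methoxyphenyl and 2,4-difluorophenyl groups. Also open, on these data alone, is whether an amine, a carboxylic acid or a longer chain in place of the methyl group of compound 1 would give a readable value in this assay, and whether any such value would be lower than that of compound 1.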